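A few compounds are considered here, and "the series" means these few. Any claim that something is new, unique, unknown or untested is made for them only; others in the source may bear on it.

In a physicochemical assay for lipophilicity, at pH 7.4 (a lower number here means a more polar compound, a higher number a more lipophilic compound), compound 1 `Fc1ccc(OCc2cc(OCC(F)(F)F)nc(-c3ccccn3)n2)c(F)c1F` gives > 4.9 as a limit of the assay and not a number. Among the compounds with values here, compound 2 `N#CCC1(COc2cc(COc3ccc(F)c(F)c3F)nc(-c3ccccn3)n2)COC1` gives 3.3 as the only exact number so far. Compound 3 `Fc1ccc(OCc2cc(OCC3(F)COC3)nc(-c3ccccn3)n2)c(F)c1F` differs from compound 2 by a single swap fluoro in place of cyanomethyl on a saturated ring carbon that puts fluoro in place of cyanomethyl on a saturated ring carbon. Within the data shown here, the only measured step of a number at least 1.60 log units lower from compound 1 to compound 2 (beyond the scatter) was large, but it replaced trifluoromethyl with the whole 3-(cyanomethyl)oxetan-3-yl group, whereas compound 3 keeps the ring. A far smaller change is therefore expected, namely a number 0.30 log units higher from compound 2 to compound 3 (within the scatter) in this assay as a modest rise. For compound 3 the estimated value is 3.6 (range 3.1 to 4.1).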

Compound 3, distribution coefficient: 4
For compound 3 the middle estimate is 0.40 log units below the measured one, within the range that was stated.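

Keeping the four-membered ring and changing only the group on its saturated ring carbon still moves the number in this assay: fluoro in place of cyanomethyl gives a number 0.70 log units higher from compound 2 to compound 3 (beyond the scatter). The smaller 3-fluorooxetan-3-yl group, put in place of trifluoromethyl, also gives a number at least 0.90 log units lower from compound 1 to compound 3 (beyond the scatter), so this lowering is not confined to 3-(cyanomethyl)oxetan-3-yl. Compound 1 stands at a limit of the assay and not a number, so this drop has no known upper end: the limit of > 4.9 in this assay, at which 1 of the 3 values shown sits.

The compounds shown leave open how an amine or a hydroxyl group on that same ring carbon would read in this assay.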